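Permeability of a piperidinyl sulfonamide: replacing a carbamoyl group

This account rests on a few compounds, and the source may have more. Where it says the series, first, only, none or still open, it means among the compounds named here.

The series is built on a shared core carrying a nitrile and a methylimidazolylmethyl group, varied at the sulfonamide nitrogen. Compound 1 `Cn1cncc1CN1CC(N(Cc2cccc(-n3cccc3)c2)S(=O)(=O)c2ccccn2)Cc2cc(C#N)ccc21` gives 2.3 10^-6 cm/s in an ADME assay on Caco-2 cells (Homo sapiens) for permeability, in the apical to basolateral direction; a higher number here means that the compound crosses the layer faster, a lower number that the compound crosses the layer more slowly. Compound 2 `CC(C)S(=O)(=O)N1CCC(CN(C2Cc3cc(C#N)ccc3N(Cc3cncn3C)C2)S(=O)(=O)c2ccccn2)CC1` gives 0.1 10^-6 cm/s, and compound 3 `Cn1cncc1CN1CC(N(CC2CCN(C(=O)NC(C)(C)C)CC2)S(=O)(=O)c2ccccn2)Cc2cc(C#N)ccc21` gives 0.6 10^-6 cm/s. Compound 3 therefore stands second highest of the three: compound 1 lies a 23-fold lower number from compound 1 to compound 2 (1.36 log units; beyond the scatter) is the largest step seen, while the change a 6.0-fold higher number from compound 2 to compound 3 (0.78 log units; beyond the scatter) is modest and moves in the opposite direction.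

Compound 4 `Cn1cncc1CN1CC(N(CC2CCN(S(=O)(=O)c3ccccc3)CC2)S(=O)(=O)c2ccccn2)Cc2cc(C#N)ccc21` differs from compound 3 in one place: phenylsulfonyl in place of (tert-butyl)carbamoyl on an amine nitrogen in a ring. The step that bears on it is the one within the same six-membered non-aromatic ring, a 6.0-fold higher number from compound 2 to compound 3 (0.78 log units; beyond the scatter), where an isopropylsulfonyl gave a lower number than the (tert-butyl)carbamoyl. Compound 4 carries a phenylsulfonyl, again a sulfonyl, so a step downward from compound 3 is expected, though the aromatic ring makes it uncertain whether it will reach as far down as compound 2.

The estimate for compound 4 in this assay is 0.3 10^-6 cm/s, with a range from 0.08 10^-6 cm/s to 1.2 10^-6 cm/s, which is expected to correspond to a step of a 2.0-fold lower number from compound 3 to compound 4 (0.30 log units; within the scatter).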

Compound 4, apparent permeability: 0.1 10^-6 cm/s
Compound 4: the middle estimate sits 3.0-fold (0.48 log units) above what was measured; measured number inside the range.
By their numbers in this assay, from the lowest: compounds 2 and 4 (each within the scatter of the next); then compound 3; then compound 1.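

On an amine nitrogen in a ring, phenylsulfonyl in place of (tert-butyl)carbamoyl gives in this assay a 6.0-fold lower number from compound 3 to compound 4 (0.78 log units; beyond the scatter) and thus matches in size the step between isopropylsulfonyl and (tert-butyl)carbamoyl at the same place. Within the data shown here, the group on the sulfonyl sulfur changes here for the first time, and no change at the digits printed from compound 2 to compound 4 (within the scatter) means that phenyl and isopropyl cannot be told apart at this position in this read-out. Among these three compounds, which differ only at this nitrogen, both sulfonyl compounds give a lower number than the carbamoyl compound 3 and none goes against that pattern, although it rests on a single carbamoyl example.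

On these data alone, it remains open whether an acetyl group, a methylcarbamoyl group or a phenylcarbamoyl group on the same nitrogen would stay level with compound 3 or fall to the level of the two sulfonyl compounds, and whether a methylsulfonyl group would also stay at that lower level. The material shown holds no measurement that explains why the carbamoyl and sulfonyl compounds differ.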